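Fused Dioxin Ring in Place of Fluoromethoxyphenyl

A few compounds are considered here, and "the series" means these few. Any claim that something is new, unique, unknown or untested is made for them only; others in the source may bear on it.

Compound 1 `COc1cc(OCC(=O)Nc2cccc(NC(=O)c3ccc(N(C)C)cc3)c2)ccc1C=O` gives 306 nM in an assay on isolated protein for inhibition of Rho-associated protein kinase 2 (Homo sapiens), read by scintillation counting, radiometric assay and 33P incorporation, with a stated time of 40 min, in the presence of a further agent that is not named here; a lower number here means a stronger inhibitor, a higher number a weaker inhibitor.
Compound 2 `COc1ccc(OCC(=O)Nc2cccc(NC(=O)c3ccc(N(C)C)cc3)c2)cc1OC` reaches only a limit of the assay, > 10000 nM.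
Compound 3 `COc1ccc(OCC(=O)Nc2cccc(NC(=O)c3ccc(N(C)C)cc3)c2)cc1F` gives 652 nM.

Of the two numbers, compound 3 has the higher one, sitting a 2.1-fold higher number from compound 1 to compound 3 (0.33 log units; beyond the scatter). Compound 4 `CN(C)c1ccc(C(=O)Nc2cccc(NC(=O)COc3ccc4c(c3)OCCO4)c2)cc1` differs from it by 2,3-dihydro-1,4-benzodioxin-6-yl in place of 3-fluoro-4-methoxyphenyl on an oxygen on a saturated carbon. Among the compounds with values here, two measured steps bear on this: the aryl swap a 2.1-fold higher number from compound 1 to compound 3 (0.33 log units; beyond the scatter) was modest, whereas the step of an at least 15-fold lower number from compound 2 to compound 3 (1.18 log units; beyond the scatter) was large, and compound 2, whose ring carries two oxygens as the entering group does, only reached the limit (the limit of > 10000 nM in this assay, at which 1 of the 3 values shown sits). A large rise in the number is therefore expected, a 6.1-fold higher number from compound 3 to compound 4 (0.79 log units; beyond the scatter), with a real chance of another limit. Compound 4 is estimated at 4000 nM, between 1000 nM and 20000 nM.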

Compound 4, half-maximal inhibitory concentration: > 10000 nM
Compound 4 was reported as a limit; the forecaster's own chance of this, stated with the estimate: 35%; at least 2.5-fold (0.39 log units) between middle value and limit.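

Putting 2,3-dihydro-1,4-benzodioxin-6-yl on this oxygen costs far more than the earlier fluoro swap suggested, with an at least 15-fold higher number from compound 3 to compound 4 (1.18 log units; beyond the scatter), and the comparison with the formyl-bearing aryl group gives an at least 32-fold higher number from compound 1 to compound 4 (1.51 log units; beyond the scatter). Tying the oxygens into a ring thus gives no readable number, just as the open 3,4-dimethoxyphenyl group gave none. Compound 4 stands at a limit, as does compound 2, so the step between them cannot be read: the limit of > 10000 nM in this assay, at which 2 of the 4 values shown sit.

On these data alone, how far either compound lies past that limit stays open. So does whether an amine or a carboxylic acid in place of the formyl would keep the number of compound 1.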